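Swapping fluoro for chloro at the limit of the assay

The source may report more compounds than this note shows. Statements on the series, on what has been measured and on what is new or still open speak of the compounds shown alone.

In a functional assay on PANC-1 cells (Homo sapiens) for cytotoxicity, read by WST assay, with a stated time of 24 h (on this read-out lower numbers stand for stronger inhibition and higher numbers for weaker inhibition), compound 1 `O=C(CCCCCCCCCc1ccccc1)N1CCCCC1` reports only a limit, > 100000 nM. Compound 2 `O=C(CCCCCCCCc1ccccc1F)N1CCCCC1` gives an actual number, 98900 nM. Compound 3 `O=C(CCCCCCCCc1cccc(F)c1)N1CCCCC1` also reports only a limit, > 100000 nM. The series is thus marked by the limit of > 100000 nM in this assay, at which 2 of the 3 values shown sit.

Compound 4 `O=C(CCCCCCCCc1cccc(Cl)c1)N1CCCCC1` differs from compound 3 by one swap, chloro in place of fluoro on an aromatic carbon. Going by the values given here, no measured step makes this swap. The closest steps are a number no higher from compound 1 to compound 2 (the limit leaves the size open), a step that the two limits leave unreadable from compound 1 to compound 3 and a number no lower from compound 2 to compound 3 (the limit leaves the size open), and none of them has a readable size. They give no firm direction, so only a modest shift is expected, and compound 4 may well report only a limit too. The value of compound 2, 98900 nM, suggests that a number of similar size is the likeliest outcome. The estimated step is an at least 1.3-fold lower number from compound 3 to compound 4 (0.12 log units; that floor lies within the scatter).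

For compound 4 the expected value is 75000 nM, with an estimated range from 30000 nM to 150000 nM.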

Compound 4, half-maximal inhibitory concentration: > 100000 nM
Compound 4 was reported as a limit; the forecaster's own chance of this, stated with the estimate: 45%; middle value at least 1.3-fold (0.12 log units) away from the limit.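

In this assay compound 4 reports only a limit, > 100000 nM. Chloro in place of fluoro at this aromatic carbon therefore yields no measurable number, and the series gathers further at a single value: the limit of > 100000 nM in this assay, at which 3 of the 4 values shown sit. Going by these compounds alone, the only step with a direction is a number no lower from compound 2 to compound 4 (the limit leaves the size open), and neither this step nor the others can be read for size.

From the compounds shown here alone, whether fluoro and chloro differ at all on this ring stays open, as compound 3 and compound 4 both give only limits. Also open, going by these compounds, is whether an amine or a carboxylic acid at the same ring carbon would bring a measurable number in this assay.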